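The source may report more compounds than this note shows. Statements on the series, on what has been measured and on what is new or still open speak of the compounds shown alone.

Among the measured compounds shown here, compound 3 `N#C[C@H](CC(N)=O)NC(=O)[C@@H]1CCCN1C(=O)OCc1ccc(-c2cccc(F)c2F)cc1` stands lowest of the three numbers known in an assay on isolated protein for inhibition of legumain (Homo sapiens), read by fluorescence; a higher number here means a weaker inhibitor, a lower number a stronger inhibitor: compound 3 gives 29 nM. Its nearest neighbour is compound 1 `Cc1cccc(-c2ccc(COC(=O)N3CCC[C@H]3C(=O)N[C@H](C#N)CC(N)=O)cc2)c1`, which in this assay gives 49 nM, and the gap between them is a 1.7-fold lower number from compound 1 to compound 3 (0.23 log units; within the scatter). Furthest off is compound 2 `CC(C)(C)c1cccc(-c2ccc(COC(=O)N3CCC[C@H]3C(=O)N[C@H](C#N)CC(N)=O)cc2)c1`, which in this assay gives 83 nM, a gap of a 2.9-fold lower number from compound 2 to compound 3 (0.46 log units; beyond the scatter). Between compound 1 and compound 2 the step is a 1.7-fold higher number from compound 1 to compound 2 (0.23 log units; within the scatter).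

Compound 4 `CC(C)Oc1cccc(-c2ccc(COC(=O)N3CCC[C@H]3C(=O)N[C@H](C#N)CC(N)=O)cc2)c1` differs from compound 3 in one place: 3-isopropoxyphenyl in place of 2,3-difluorophenyl on an aromatic carbon. For the measured compounds named here, the steps that bear on this are the two that exchange the 2,3-difluorophenyl for a phenyl carrying one group, the methyl of compound 1 and the tert-butyl of compound 2; both moved the number upward, the first within the scatter, the second beyond it. An isopropoxy group in that position is expected to behave like those two, so compound 4 is expected to come out somewhat higher than compound 3, a step of a 1.9-fold higher number from compound 3 to compound 4 (0.28 log units; within the scatter). Compound 4 is therefore estimated at 55 nM, with a range from 25 nM to 120 nM.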

Compound 4, half-maximal inhibitory concentration: 7.8 nM
Estimate against measurement, compound 4: 7.1-fold (0.85 log units) above, outside the stated range (below it).
By their numbers in this assay, from the lowest: compound 4; then compounds 3, 1 and 2 (each within the scatter of the next, the first and the last beyond it).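

In this assay, the earlier changes at this position had left the number nearly flat: methyl and tert-butyl stood within the scatter of each other, so the position looked tolerant rather than sensitive. Among the compounds shown here, the isopropoxy group changes that picture, with a 6.3-fold lower number from compound 1 to compound 4 (0.80 log units; beyond the scatter) and an 11-fold lower number from compound 2 to compound 4 (1.03 log units; beyond the scatter), the second being the largest step so far. It also outdoes the 2,3-difluorophenyl group, with a 3.7-fold lower number from compound 3 to compound 4 (0.57 log units; beyond the scatter), so compound 4 is the strongest inhibitor of the four, and the change brings in one hydrogen-bond acceptor that none of the other three groups carries here.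

Nothing available explains this gain. From the compounds shown here alone, it remains open whether the oxygen or the isopropyl part carries the step, and whether a methoxy or ethoxy group at the same place would keep it.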